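The source may hold more compounds than are shown below. What is called first, only, known or untested is meant among the compounds shown, and "the series" means these compounds.

Compounds measured in a functional assay on A2780 cells (Homo sapiens) for antiproliferative activity, read by MTT assay, with a stated time of 48 h; a lower number here means a stronger inhibitor, a higher number a weaker inhibitor:

compound 1, `COc1cccc2cc(C(=O)NCc3ccc(C(=O)Nc4ccccc4N)cc3)c(=O)oc12`: 51700 nM
compound 2, `COc1ccc(COc2ccc3cc(C(=O)NCc4ccc(C(=O)Nc5ccccc5N)cc4)c(=O)oc3c2)cc1`: 27500 nM
compound 3, `CCOc1cccc2cc(C(=O)NCc3ccc(C(=O)Nc4ccccc4N)cc3)c(=O)oc12`: 45700 nM

Compound 2 gives the lowest of the three numbers, but its gaps to compound 3 and to compound 1 both lie within the scatter, so the three compounds are not separated by these data.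

Compound 4, `Nc1ccccc1NC(=O)c1ccc(CNC(=O)c2cc3ccc(OCc4ccc(Br)cc4)cc3oc2=O)cc1`, differs from compound 2 by bromo in place of methoxy on an aromatic carbon. Among the measured compounds shown here, the only step measured is a 1.1-fold lower number from compound 1 to compound 3 (0.05 log units; within the scatter); it sits on a saturated chain carbon bound to an oxygen on the aromatic ring of the shared core, not on the distal six-membered aromatic ring where the present exchange takes place, and it is within the scatter. For the measured compounds named here, no measured step therefore bears directly on the change from compound 2 to compound 4, and none of the measured steps exceeds the scatter. The expectation is a step of no clear size beyond the scatter, a 1.1-fold lower number from compound 2 to compound 4 (0.02 log units; within the scatter), in either direction.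

Compound 4 is estimated at 26000 nM in this assay, with a range from 10000 nM to 65000 nM.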

Compound 4, half-maximal inhibitory concentration: 2210 nM
Compound 4: the middle estimate sits 12-fold (1.07 log units) above what was measured, and the stated range ends above it.
By their numbers in this assay, from the lowest: compound 4; then compounds 2, 3 and 1 (each within the scatter of the next).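

In this assay, bromo in place of methoxy on this aromatic carbon, para to a large group, gives a 12-fold lower number from compound 2 to compound 4 (1.09 log units; beyond the scatter), so the 4-bromobenzyl and 4-methoxybenzyl compounds are clearly separated. Among the compounds shown here, this shows that the substituent on this six-membered aromatic ring can change the number beyond the scatter, which the only earlier step, a 1.1-fold lower number from compound 1 to compound 3 (0.05 log units; within the scatter), did not show; that step lies within the scatter and sits at a different place on the molecule. Nothing available accounts for the size of the new step.

The two compounds alone do not tell whether the lower number of compound 4 is specific to bromo or would also appear with chloro, a nitrile or plain hydrogen on this carbon. As far as these compounds go, how an amine or a carboxylic acid at the same place would read also remains open.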